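From dipropylamino to (dipentylamino)methyl in compound 3

The source may report more compounds than this note shows. Statements on the series, on what has been measured and on what is new or still open speak of the compounds shown alone.

In a functional assay on DU-145 cells (Homo sapiens) for antiproliferative activity, read by WST assay, with a stated time of 3 days (on this read-out lower numbers stand for stronger inhibition and higher numbers for weaker inhibition), compound 1 `CCCCOc1c(-c2cc(OC)c(OC)c(OC)c2)oc2ccccc2c1=O` gives only a limit, > 50000 nM. Among the compounds with values here, compound 2 `CCCN(CCC)CCCCOc1c(-c2cc(OC)c(OC)c(OC)c2)oc2ccccc2c1=O` gives 35800 nM, the only exact number so far. Within the data shown here, the single measured step, an at least 1.3-fold lower number from compound 1 to compound 2 (0.14 log units; that floor lies within the scatter), offers weak guidance, yet it is all there is. Compound 3 `CCCCCN(CCCCC)CCCCCOc1c(-c2cc(OC)c(OC)c(OC)c2)oc2ccccc2c1=O` changes the same side chain: (dipentylamino)methyl in place of dipropylamino on a saturated chain carbon, four bonds along the chain from an oxygen on an aromatic ring. With so little to go on, a modest move towards stronger inhibition is expected, and the expected step is a 2.4-fold lower number from compound 2 to compound 3 (0.38 log units; beyond the scatter). For compound 3 the estimated value is 15000 nM, within an expected range of 3000 nM to 50000 nM.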

Compound 3, half-maximal inhibitory concentration: 11700 nM
Estimate against measurement, compound 3: 1.3-fold (0.11 log units) above, and the stated range covers the measured number.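

In this assay, within the data shown here, (dipentylamino)methyl in place of dipropylamino gives a 3.1-fold lower number from compound 2 to compound 3 (0.49 log units; beyond the scatter), the first step here between two exact numbers and the first to clear the scatter. Against the compound with hydrogen at this place, the change gives an at least 4.2-fold lower number from compound 1 to compound 3 (0.63 log units; beyond the scatter), which is a floor and not a true size because one end of it is a limit: the limit of > 50000 nM in this assay, at which 1 of the 3 values shown sits.

This single change lengthens the chain and enlarges the groups on the nitrogen together, and the compounds shown do not separate the two. Going by these compounds, how a ring amine such as piperidine would behave at this place also remains open.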